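The source may report more compounds than this note shows. Statements on the series, on what has been measured and on what is new or still open speak of the compounds shown alone.

Compound 1 `CC1(C)CC(C)(C)c2cc(NC(=O)Nc3ccc(OC(F)(F)F)cc3)ccc2O1` gives 4560 nM in a functional assay on A2780 cells (Homo sapiens) for inhibition, with a stated time of 72 h; a lower number here means a stronger inhibitor, a higher number a weaker inhibitor.
Compound 2 `CCOC(=O)c1ccc(N/C(S)=N/c2ccc3c(c2)C(C)(C)CC(C)(C)O3)cc1` gives 4300 nM in this assay.
Compound 3 `CC1(C)CC(C)(C)c2cc(NC(=O)Nc3ccc([N+](=O)[O-])cc3)ccc2O1` gives 4100 nM in this assay.

For the measured compounds named here, the three numbers lie within the scatter of one another, so compound 3 cannot be set apart from compound 1 or compound 2; the only step among them, a 1.1-fold lower number from compound 1 to compound 3 (0.05 log units; within the scatter), did not move the number beyond the scatter. Compound 4 `CC1(C)CC(C)(C)c2cc(NC(=O)Nc3ccc(C#N)cc3)ccc2O1` differs from compound 3 by cyano in place of nitro on an aromatic carbon. Going by the values given here, no measured step exchanges a nitro for a cyano, and the one step at this aromatic carbon stayed within the scatter, so no shift beyond the scatter is expected in this assay. Compound 4 is therefore expected to give 4200 nM, between 1800 nM and 9500 nM. The expected step is a 1.0-fold higher number from compound 3 to compound 4 (0.01 log units; within the scatter).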

Compound 4, half-maximal inhibitory concentration: 4700 nM
Estimate against measurement, compound 4: 1.1-fold (0.05 log units) below; low and high end bracket the measured number.
By their numbers in this assay, from the lowest: compounds 3, 2, 1 and 4 (each within the scatter of the next).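

In this assay, cyano in place of nitro on this aromatic carbon gives a 1.1-fold higher number from compound 3 to compound 4 (0.06 log units; within the scatter) and cyano in place of trifluoromethoxy gives a 1.0-fold higher number from compound 1 to compound 4 (0.01 log units; within the scatter) at the same carbon, so both exchanges stay within the scatter. Where only one exchange at this carbon could be read before, three groups there, trifluoromethoxy, nitro and cyano, now cannot be told apart. From the compounds shown here alone, whether an amine or a carboxylic acid on this carbon would move the number beyond the scatter stays open. No evidence is at hand that explains this flat result.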